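Methyl next to the ring heteroatom on two cores

The compounds below may be only part of what the source reports. "The series", "measured", "known", "first", "only" and "open" are said of these compounds alone.

Compound 1 `COc1cc(/C=C/Cc2cc(O)c3ccsc3c2)cc(OC)c1OC` in a functional assay on BMEC cells (Bos taurus) for antiproliferative activity (on this read-out higher numbers stand for weaker inhibition and lower numbers for stronger inhibition), gives 38700 nM. Compound 3 `COc1cc(/C=C/Cc2cc(O)c3cc(C)sc3c2)cc(OC)c1OC` differs from it by methyl in place of hydrogen on an aromatic carbon and in this assay gives 840 nM; the step is a 46-fold lower number from compound 1 to compound 3 (1.66 log units; beyond the scatter). Compound 2 `COc1cc(/C=C\Cc2cc(O)c3ccoc3c2)cc(OC)c1OC` rests on a different core; the difference between the two cores is not broken down here. In this assay compound 2 gives 49 nM, the lowest of the three numbers, well beyond the scatter from both others.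

Compound 4 `COc1cc(/C=C\Cc2cc(O)c3cc(C)oc3c2)cc(OC)c1OC` is not yet measured and differs from compound 2 by methyl in place of hydrogen on an aromatic carbon. The surroundings of the place are not identical: in compound 3 the five-membered aromatic ring holds one sulfur and the methyl sits next to the ring sulfur, whereas in compound 4 the ring holds one oxygen and the methyl sits next to the ring oxygen. It is therefore the same kind of change, not the same change, and it has one measured precedent only.

The step is expected to be a 4.1-fold lower number from compound 2 to compound 4 (0.61 log units; beyond the scatter), in the direction of the earlier one but smaller, since the precedent stands on another core and compound 2 already gives 49 nM. Compound 4 is estimated at 12 nM, between 2 nM and 60 nM.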

Compound 4, half-maximal inhibitory concentration: 93 nM
The estimate for compound 4 lay 7.8-fold (0.89 log units) below the measured number, outside the stated range (above it).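

In this assay methyl in place of hydrogen on an aromatic carbon of the core of compound 2 gives a 1.9-fold higher number from compound 2 to compound 4 (0.28 log units; within the scatter), so this read-out does not separate the two compounds. The change therefore did not carry over from one core to the other with its earlier size: the same change on two cores in this assay, a 46-fold lower number (1.66 log units; beyond the scatter) from compound 1 to compound 3 and a 1.9-fold higher number (0.28 log units; within the scatter) from compound 2 to compound 4, 87-fold (1.94 log units) apart, beyond the scatter of two such steps. This does not show which difference between the two cores accounts for the gap, as no measured pair here isolates any one of them, and each core rests on a single step, so neither result can be taken as the rule for its core.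

Open, from the compounds shown here alone, is whether ethyl, chlorine or a methoxy group at this same place, on an aromatic carbon next to the ring oxygen, would also leave the number on the core of compound 2 within the scatter. Also open, going by these compounds, is what an amine or a carboxylic acid in that place would do on either core, and whether the hydroxyl of the shared fused system can be replaced by a methoxy group or an amine.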